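Varying the amino group on the aromatic carbon

The compounds below may be only part of what the source reports. "The series", "measured", "known", "first", "only" and "open" are said of these compounds alone.

Within the data shown here, compound 2 `CN(CCCN1CCCCC1)c1cccc(C(=O)N2CCc3ccc(OS(N)(=O)=O)cc3C2)c1` gives 24.1% in an assay on HEK293 cells for inhibition of Steryl-sulfatase (Homo sapiens), tested at 0.1 uM (a higher number here means a stronger effect of the compound at the concentration tested, a lower number a weaker effect), the higher of the two numbers measured so far; compound 1 `CCN(Cc1ccc(F)cc1)c1cccc(C(=O)N2CCc3ccc(OS(N)(=O)=O)cc3C2)c1` gives 10.9% in this assay. Among the measured compounds shown here, the single step known is a number 13.2 percentage points higher from compound 1 to compound 2 (beyond the scatter). Compound 3 `CC(C)CCN(CCC(C)C)c1cccc(C(=O)N2CCc3ccc(OS(N)(=O)=O)cc3C2)c1` differs from compound 2 by diisopentylamino in place of methyl(3-(piperidin-1-yl)propyl)amino on an aromatic carbon. For the measured compounds named here, only the step from compound 1 to compound 2 bears on this change: it introduced the group that now leaves, so part of that gain is expected to be given back, and the expected step is a number 11.1 percentage points lower from compound 2 to compound 3 (beyond the scatter). Compound 3 is therefore estimated at 13%, within 4% to 24%.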

Compound 3, a percentage reported as inhibition, at one concentration (the size of the read-out at that concentration, not a potency): 32.3%
Compound 3: middle estimate off by 19.3 percentage points, on the low side; measured number above the stated range.
By their numbers in this assay, from the lowest: compound 1; then compounds 2 and 3 (each within the scatter of the next).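

In this assay, methyl(3-(piperidin-1-yl)propyl)amino is not required at this aromatic carbon: diisopentylamino, which has no ring, gives a number 8.2 percentage points higher from compound 2 to compound 3 (within the scatter). Against ethyl(4-fluorobenzyl)amino, the same diisopentylamino group gives a number 21.4 percentage points higher from compound 1 to compound 3 (beyond the scatter), so two quite different amino groups now stand clear of compound 1. No measurement at hand accounts for these differences.

Open: how a shorter chain such as diethylamino, an unsubstituted amine or a carboxylic acid on this aromatic carbon would read out on the same core.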